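Amide aryl swap on the shared core: compound 3 to compound 4

A few compounds are considered here, and "the series" means these few. Any claim that something is new, unique, unknown or untested is made for them only; others in the source may bear on it.

Three compounds of the series have numbers in a functional assay on A549 cells (Homo sapiens) for antiproliferative activity, read by MTT assay, with a stated time of 72 h; a lower number here means a stronger inhibitor, a higher number a weaker inhibitor. Compound 1 `COc1ccc(C(=O)Nc2cc(Nc3nccc(-c4cn(C)c5ccccc45)n3)c(OC)cc2F)nc1` gives 8200 nM. Compound 2 `COc1cc(N(C)CCN(C)C)c(NC(=O)c2ccncc2)cc1Nc1nccc(-c2cn(C)c3ccccc23)n1` gives 10400 nM, and compound 3 `COc1cc(N(C)C)c(NC(=O)c2ccncc2)cc1Nc1nccc(-c2cn(C)c3ccccc23)n1` gives 9000 nM. Among the measured compounds shown here, the one step computed between measured compounds, a 1.2-fold lower number from compound 2 to compound 3 (0.06 log units; within the scatter), is within the scatter. Compound 3 thus holds the second highest of the three numbers, with compound 1 nearest and compound 2 furthest, both within the scatter of compound 3, so no order among the three can be read from this assay.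

Compound 4 `COc1ccc(C(=O)Nc2cc(Nc3nccc(-c4cn(C)c5ccccc45)n3)c(OC)cc2N(C)C)nc1` differs from compound 3 by 5-methoxypyridin-2-yl in place of pyridin-4-yl on a carbonyl carbon. For the measured compounds named here, no measured step touches the amide aryl: the only computed step, from compound 2 to compound 3, concerns the chain on the aromatic nitrogen and is within the scatter. Compound 1 carries the same 5-methoxypyridin-2-yl carbonyl as compound 4 but differs from it elsewhere, and its value sits within the scatter of compound 3. The series therefore offers no ground for a shift beyond the scatter, and the expected step of no change at the digits printed from compound 3 to compound 4 (within the scatter) is none beyond it. Compound 4 is estimated at 9000 nM in this assay, with a range from 4000 nM to 20000 nM.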

Compound 4, half-maximal inhibitory concentration: 5150 nM
Estimate against measurement, compound 4: 1.7-fold (0.24 log units) above, and the stated range covers the measured number.
By their numbers in this assay, from the lowest: compounds 4, 1, 3 and 2 (each within the scatter of the next, the first and the last beyond it).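

Notes on the amide aryl and the aromatic carbon: in this assay the swap to 5-methoxypyridin-2-yl in place of pyridin-4-yl on the carbonyl carbon, read as a 1.7-fold lower number from compound 3 to compound 4 (0.24 log units; within the scatter) on the shared core, gives the first reading at this position and shows that the larger aryl with its added methoxy is accepted there without a shift beyond the scatter. Among the compounds shown here, the same compound also gives the first reading on the aromatic carbon that carries fluoro in compound 1, where the step of a 1.6-fold lower number from compound 1 to compound 4 (0.20 log units; within the scatter) for dimethylamino in place of fluoro likewise stays inside the scatter, so neither place has yet moved the number by more than repeat measurements would. Nothing at hand bears on the reason for either step.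

As far as these compounds go, whether a phenyl, a 5-aminopyridin-2-yl or a pyridine carrying a carboxylic acid on the same carbonyl would move the number beyond the scatter stays open. So does whether a morpholine or a piperazine on the aromatic carbon, in place of dimethylamino or fluoro, would do so.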